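A few compounds are considered here, and "the series" means these few. Any claim that something is new, unique, unknown or untested is made for them only; others in the source may bear on it.

Compound 1 `CN(Cc1ccc(C(=O)O)cc1)c1ccc(OCc2c(-c3c(Cl)cccc3Cl)noc2C2CC2)nc1C(F)(F)F` stands highest of the two compounds measured in a functional assay on HEK293 cells for agonist activity at Bile acid receptor (Homo sapiens) (a higher number here means a larger maximal response, a lower number a smaller maximal response), where compound 1 gives 81%. The nearest number belongs to compound 2 `CN(Cc1ccc(C(=O)NCCS(=O)(=O)O)cc1)c1ccc(OCc2c(-c3c(Cl)cccc3Cl)noc2C2CC2)nc1C(F)(F)F`, which gives 57% in this assay; the step of a number 24 percentage points lower from compound 1 to compound 2 (beyond the scatter) goes with (2-sulfoethyl)amino in place of hydroxy on a carbonyl carbon. Compound 3 `CCN(Cc1ccc(C(=O)O)cc1)c1ccc(OCc2c(-c3c(Cl)cccc3Cl)noc2C2CC2)nc1C(F)(F)F` has not yet been measured in this assay. It differs from compound 1 by methyl in place of hydrogen on a saturated chain carbon bound to a nitrogen on an aromatic ring. Within the data shown here, no measured step touches this place: the single known step concerns the group on the carbonyl carbon and offers no direct guide to a change at the saturated chain carbon bound to the ring nitrogen. The working expectation is therefore a step that stays within the scatter, with a modest lean downward as compound 1 already holds the highest number seen. The step from compound 1 to compound 3 is expected to be a number 5 percentage points lower from compound 1 to compound 3 (within the scatter). For compound 3 the expected value in this assay is 76%, in the range 58% to 94%.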

Compound 3, largest response reached (reported as efficacy), in percent of the reference or control that the assay uses: 54%
Compound 3: the middle estimate sits 22 percentage points above what was measured; the whole stated range lies above it.
By their numbers in this assay, from the lowest: compounds 3 and 2 (each within the scatter of the next); then compound 1.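

In this assay, the saturated chain carbon bound to a nitrogen on an aromatic ring proves to be a sensitive place: methyl in place of hydrogen, which reads as methyl to ethyl one bond further out, gives a number 27 percentage points lower from compound 1 to compound 3 (beyond the scatter) for the addition of 1 carbon. The maximal response therefore depends on this part of the molecule as well as on the group on the carbonyl carbon, where the earlier change gave a number 24 percentage points lower from compound 1 to compound 2 (beyond the scatter) with a much larger replacement group. Nothing available bears on why the response falls at this place.

From the compounds shown here alone, whether a longer chain such as propyl, or a cyclopropyl group, at this place lowers the response further remains open, as does the result of a plain hydrogen in place of the methyl of compound 1. Also open, going by these compounds, is how the ethyl change and the (2-sulfoethyl)amino change behave when combined in one compound.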